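A few compounds are considered here, and "the series" means these few. Any claim that something is new, unique, unknown or untested is made for them only; others in the source may bear on it.

Working notes on a small set of salicylanilides sharing the hydroxy-benzamide core. Compound 1 `N#Cc1ccc(NC(=O)c2cc(Cc3ccccc3)ccc2O)cc1` is the reference for this step. Within the data shown here, in a functional assay on HL-60 cells (Homo sapiens) for cytotoxicity, read by luminescence and CellTiter-Glo, with a stated time of 3 days (on this read-out lower numbers stand for stronger inhibition and higher numbers for weaker inhibition), compound 1 gives 1740 nM, the highest of the three numbers measured so far. Compound 2 `N#Cc1ccc(NC(=O)c2ccc(C(F)(F)F)cc2O)cc1` in this assay gives 1030 nM, a number that sits within the usual scatter of that of compound 1, so no order between the two is claimed. Compound 3 `O=C(Nc1ccc(OC(F)(F)F)c(Cl)c1)c1cc(Cl)ccc1O` in this assay gives 450 nM, and the gap from compound 1 to compound 3 is beyond the scatter, so compound 3 is the stronger of that pair on these numbers. Among the measured compounds shown here, no two of the measured compounds differ in one place only, so no single-point step is available as a guide.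

Compound 4 `N#Cc1ccc(NC(=O)c2cc(C(F)(F)F)ccc2O)cc1` has not been measured. It differs from compound 1 in one place: trifluoromethyl in place of benzyl on an aromatic carbon. Compound 2 carries a trifluoromethyl group on the same core and gives a number within the scatter of compound 1, and the change is small in count, so the step from compound 1 to compound 4 is expected to be at most modest, toward a lower number if anything. Compound 4 is therefore expected to give about 1100 nM in this assay, with a range from 450 nM to 2700 nM, meaning an expected step of a 1.6-fold lower number from compound 1 to compound 4 (0.20 log units; within the scatter).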

Compound 4, half-maximal inhibitory concentration: 3120 nM
Compound 4: middle estimate off by 2.8-fold (0.45 log units), on the low side; measured number above the stated range.
By their numbers in this assay, from the lowest: compound 3; then compounds 2, 1 and 4 (each within the scatter of the next, the first and the last beyond it).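

In this assay, among these compounds, replacing benzyl with trifluoromethyl on this aromatic carbon, para to a hydroxy group, gives a 1.8-fold higher number from compound 1 to compound 4 (0.25 log units; within the scatter), the first single-point step and one that sets no order between the pair. Benzyl, with its 7 heavy atoms and six-membered aromatic ring, gives way to trifluoromethyl, with 4 heavy atoms and no ring, so on this pair the loss of that ring from this position does not move the number beyond the usual scatter. No measured data on any property of these compounds or their groups bear on this result, so the step stands here as an observation without an explanation.

The compounds shown leave open whether an amine, a carboxylic acid or a longer chain, such as n-butyl, on this same aromatic carbon would give a step beyond the scatter from compound 1. They also leave open whether the exchange of benzyl for trifluoromethyl would give a similar step if the nitrile of compound 1 were replaced by a carboxylic acid.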